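Swapping propanoyl for acetyl on a pyrazoline anti-inflammatory series

The source may hold more compounds than are shown below. What is called first, only, known or untested is meant among the compounds shown, and "the series" means these compounds.

Of the compounds shown here, three sharing one core have been tested in a functional assay on the whole organism (strain Wistar) for inhibition, with Rattus norvegicus as the target, read by paw edema, with stated times of 30 min and 60 min, at a dose of 50 mg/kg by the oral route; on this read-out lower numbers stand for less inhibition and higher numbers for more inhibition at the one dose given (going by the name of the read-out). Compound 1 `CCC(=O)N1N=C(c2ccc(C)cc2)CC1c1cn(-c2ccccc2)nc1-c1ccc(Cl)c(Cl)c1` gives 61.1% in this assay. Compound 2 `CC(=O)N1N=C(c2ccc(C)cc2)CC1c1cn(-c2ccccc2)nc1-c1ccc(Cl)c(Cl)c1` gives 59.5% in this assay. Compound 3 `CCC(=O)N1N=C(c2ccc(F)cc2)CC1c1cn(-c2ccccc2)nc1-c1ccc(Cl)c(Cl)c1` gives 63.4% in this assay. Compound 4 `CC(=O)N1N=C(c2ccc(F)cc2)CC1c1cn(-c2ccccc2)nc1-c1ccc(Cl)c(Cl)c1` has not yet been measured.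

Compound 2 differs from compound 1 by hydrogen in place of methyl on a saturated chain carbon bound to a carbonyl carbon. This change produced a number 1.6 percentage points lower from compound 1 to compound 2 (within the scatter). Compound 3 differs from compound 1 by fluoro in place of methyl on an aromatic carbon, and that change produced a number 2.3 percentage points higher from compound 1 to compound 3 (within the scatter). All three measured numbers sit within the usual scatter of one another, so none of them can be said to be higher or lower than another in this assay.

Compound 4 differs from compound 3 by hydrogen in place of methyl on a saturated chain carbon bound to a carbonyl carbon. This is the same change as the one from compound 1 to compound 2, made at the same place, on a core that differs only by the fluoro in place of methyl described above. The step expected here is a number 1.6 percentage points lower from compound 3 to compound 4 (within the scatter), estimated because the same change gave a number 1.6 percentage points lower from compound 1 to compound 2 (within the scatter), a step that lies within the usual scatter. On that basis compound 4 is expected to give about 61.8% in this assay, with a likely range from 52% to 72%.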

Compound 4, a percentage reported as inhibition, in the whole organism at one dose (the size of the read-out at that dose, not a potency): 59.5%
Compound 4: middle estimate off by 2.3 percentage points, on the high side; the measured number falls inside the stated range.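

Changing propanoyl to acetyl on the core that carries fluoro gives a number 3.9 percentage points lower from compound 3 to compound 4 (within the scatter), and in this assay this step agrees with the same change on the core that carries methyl: the same change on two cores in this assay, a number 1.6 percentage points lower (within the scatter) from compound 1 to compound 2 and a number 3.9 percentage points lower (within the scatter) from compound 3 to compound 4, 2.3 percentage points apart, within the scatter of two such steps. Placing fluoro where methyl stood gives no change at the digits printed from compound 2 to compound 4 (within the scatter) on the acetyl compounds, and this step likewise agrees with its counterpart on the propanoyl compounds: the same change on two cores in this assay, a number 2.3 percentage points higher (within the scatter) from compound 1 to compound 3 and no change at the digits printed (within the scatter) from compound 2 to compound 4, 2.3 percentage points apart, within the scatter of two such steps. This agreement shows that neither change moved the number beyond the usual scatter on either core, but it does not show that either change has a real effect that carries over, since all the steps are small enough to be scatter alone.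

The compounds shown leave open whether a larger change at either place would move the number clearly, such as a longer chain like butanoyl on the carbonyl or a methoxy group or a carboxylic acid on the aromatic carbon. As far as these compounds go, only with such a clear step could carry-over from one core to another be tested properly, and whether these four compounds would separate at other doses also remains unknown.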